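Ethynyl in Place of Benzoyl on a Shared Core

This account rests on a few compounds, and the source may have more. Where it says the series, first, only, none or still open, it means among the compounds named here.

Compound 3 `Cc1nnc(SCC(=O)c2ccccc2)n1N1C(=O)c2ccccc2C1=O` is one of three close relatives measured in a functional assay on PC-3M cells (Homo sapiens) for cytotoxicity, read by MTT assay, with a stated time of 48 h; on this read-out lower numbers stand for stronger inhibition and higher numbers for weaker inhibition. In this assay compound 3 gives only a limit, > 200000 nM. Compound 1 `Cc1nnc(SCC(=O)c2ccc(Cl)cc2)n1N1C(=O)c2ccccc2C1=O` likewise gives a limit, > 200000 nM. Compound 2 `Cc1ccc(C(=O)CSc2nnc(C)n2N2C(=O)c3ccccc3C2=O)cc1` also gives a limit, > 200000 nM. The steps among these three, a step that the two limits leave unreadable from compound 1 to compound 2, a step that the two limits leave unreadable from compound 1 to compound 3 and a step that the two limits leave unreadable from compound 2 to compound 3, cannot be sized, since (the limit of > 200000 nM in this assay, at which 3 of the 3 values shown sit). Compound 4 `C#CCSc1nnc(C)n1N1C(=O)c2ccccc2C1=O` differs from compound 3 by ethynyl in place of benzoyl on a saturated chain carbon bound to a sulfur. Among the compounds with values here, all of the measured steps lie within the group that leaves here, and every one of them is unreadable, so the data offer no readable step to build on and no sign that any member of this set reaches a measurable number. Compound 4 is therefore expected to stay at the limit, with an expected step of a number no higher from compound 3 to compound 4 (the limit leaves the size open) that is none beyond the scatter. The estimate for compound 4 in this assay is 200000 nM, with an expected range from 100000 nM to 500000 nM.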

Compound 4, half-maximal inhibitory concentration: > 200000 nM
Compound 4 gave a limit, no number; the forecaster's own chance of this, stated with the estimate: 80%; the middle value lies on the limit itself.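

The steps from compound 1, compound 2 and compound 3 to compound 4 cannot be read, since all four compounds give only a limit: the limit of > 200000 nM in this assay, at which 4 of the 4 values shown sit.

The compounds shown leave open whether any group at this place on the shared core can bring a measurable value.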